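Vinyl ether series: methyl on the fused ring

The compounds below may be only part of what the source reports. "The series", "measured", "known", "first", "only" and "open" are said of these compounds alone.

Measured so far:
compound 1 `COc1ccc(Cn2c(-c3ccccc3O)c(Br)c3cc(C)ccc3c2=O)cc1` — 53000 nM
compound 2 `C=COc1ccccc1-c1c(Br)c2ccccc2c(=O)n1Cc1ccc(OC)cc1` — limit only, > 100000 nM

In a functional assay on A549 cells (Homo sapiens) for cytotoxicity, read by sulforhodamine B assay (on this read-out lower numbers stand for stronger inhibition and higher numbers for weaker inhibition), compound 1 gives 53000 nM. For compound 2 this assay yields no number, only a limit, > 100000 nM. Compound 2 therefore stands at the upper edge of the numbers shown, (the limit of > 100000 nM in this assay, at which 1 of the 2 values shown sits); nothing says how far beyond it the true value lies.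

The next compound is compound 3 `C=COc1ccccc1-c1c(Br)c2cc(C)ccc2c(=O)n1Cc1ccc(OC)cc1`. Relative to compound 2 the change is methyl in place of hydrogen on an aromatic carbon. For the measured compounds named here, no measured pair differs in this one place alone, so the size of this step has not been seen directly. Compound 1 carries the same methyl but also differs from compound 2 at the other ring, and its value cannot be read as the effect of the methyl alone.

With no measured guide, the expectation for this step is a change no larger than the scatter, in either direction. For compound 3 the expected outcome in this assay is 100000 nM, within a range of 40000 nM to 300000 nM, an expected step of a number no higher from compound 2 to compound 3 (the limit leaves the size open); a limit rather than a number is the more likely report.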

Compound 3, half-maximal inhibitory concentration: 67800 nM
Compound 3: the middle estimate sits 1.5-fold (0.17 log units) above what was measured; the range from low to high includes it.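

For the compounds shown here, compound 2 stands at > 100000 nM as a limit and not a number in this assay and so fixes only one side of this comparison. The change of methyl in place of hydrogen on an aromatic carbon therefore reads as an at least 1.4-fold lower number from compound 2 to compound 3 (0.16 log units; that floor lies within the scatter) and only as a floor, which leaves its true size open and does not establish a shift beyond the scatter. With the same methyl present in both compounds, vinyl in place of hydrogen on the oxygen gives a 1.3-fold higher number from compound 1 to compound 3 (0.11 log units; within the scatter) and so compound 1 and compound 3 cannot be told apart in this read-out, a comparison the earlier pair could not offer.

Going by these compounds alone, open is whether an amine or a chlorine on this same aromatic carbon would move the number beyond the scatter, since methyl is the only group seen there. Also open, as far as these compounds go, is whether a longer chain in place of vinyl on the oxygen would separate from compound 3 in this read-out.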